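A few compounds are considered here, and "the series" means these few. Any claim that something is new, unique, unknown or untested is made for them only; others in the source may bear on it.

In a functional assay on the whole organism for inhibition, with Rattus norvegicus as the target, with a stated time of 2 h, at a dose of 100 mg/kg by the oral route (a lower number here means less inhibition, a higher number more inhibition at the dose given (going by the name of the read-out)), compound 2 `Clc1ccc(-c2nnc(-c3nsc4ccccc34)o2)cc1` gives 13%, and compound 1 `CCc1nnc(-c2nsc3ccccc23)o1` gives 10%; the step of a number 3 percentage points higher from compound 1 to compound 2 (within the scatter) lies within the scatter, so the two stand together on what is known. Compound 3 `CCNc1nnc(-c2nsc3ccccc23)o1` differs from compound 2 by ethylamino in place of 4-chlorophenyl on an aromatic carbon. For the measured compounds named here, no measured step covers this exchange; the only step known, a number 3 percentage points higher from compound 1 to compound 2 (within the scatter), put 4-chlorophenyl in place of ethyl and did not reach beyond the scatter. The step is therefore expected to be a number 2 percentage points lower from compound 2 to compound 3 (within the scatter), nothing beyond the scatter. Compound 3 is estimated at 11%, with a range from 0% to 25%.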

Compound 3, a percentage reported as inhibition, in the whole organism at one dose (the size of the read-out at that dose, not a potency): 53%
Compound 3: the middle estimate sits 42 percentage points below what was measured, outside the stated range (above it).
By their numbers in this assay, from the lowest: compounds 1 and 2 (each within the scatter of the next); then compound 3.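

Unlike ethyl and 4-chlorophenyl, ethylamino separates from the others at this carbon in this assay: the exchange for 4-chlorophenyl gives a number 40 percentage points higher from compound 2 to compound 3 (beyond the scatter) and the exchange for ethyl gives a number 43 percentage points higher from compound 1 to compound 3 (beyond the scatter) on the same core. The second step keeps the ethyl chain and adds the linking amine nitrogen, so a change of that single atom is enough for a large step at this position. Nothing on hand accounts for the gain.

The compounds shown leave open whether the gain depends on the amine hydrogen or on the ethyl chain. An unsubstituted amino group, dimethylamino or propylamino at this carbon would separate these parts.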